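Shortening the acid-bearing side chain of compound 2

The compounds below may be only part of what the source reports. "The series", "measured", "known", "first", "only" and "open" are said of these compounds alone.

Measured compounds and their values:
compound 1 `NC(=O)C[C@H](NC(=O)CN(c1nc(Cl)nc2[nH]cnc12)C1CC1)C(=O)O` gives 17%
compound 2 `O=C(O)CC[C@H](NC(=O)CN(c1nc(Cl)nc2[nH]cnc12)C1CC1)C(=O)O` gives 30.1%
compound 3 `C[C@@H](O)[C@H](NC(=O)CN(c1ncnc2c1ncn2C1CCCCO1)C1CC1)C(=O)OCc1ccccc1` gives 10.9%

In a functional assay on the whole organism (Tail, strain ICR) with Mus musculus as the target, in the tail flick test, with a stated time of 120 min, at a dose of 25 umol/kg by the oral route (a lower number here means a weaker effect, a higher number a stronger effect of the compound at the dose given), compound 2 stands highest of the three numbers, its nearest neighbour being compound 1 with a value lower by more than the scatter, and compound 3 furthest below. Within the data shown here, the single step between compounds that differ in one place is a number 13.1 percentage points higher from compound 1 to compound 2 (beyond the scatter), a modest gain from swapping carbamoyl for carboxymethyl at the same position on the shared core's side chain.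

Compound 4 `O=C(O)C[C@H](NC(=O)CN(c1nc(Cl)nc2[nH]cnc12)C1CC1)C(=O)O` has not yet been tested. The change from compound 2 to compound 4 is carboxy in place of carboxymethyl on a saturated chain carbon, two bonds along the chain from an amide-type nitrogen and a carbonyl carbon. Among the measured compounds shown here, no measured pair shows this shortening by one chain carbon, so the step from compound 1 to compound 2 bears on it only loosely: it tells that a carboxylic acid on this arm goes with the higher number, but not what a shorter arm does. The expectation is therefore a step of no more than the scatter, a number 7.1 percentage points lower from compound 2 to compound 4 (within the scatter), with a slight lean downward since compound 2 is the top of a small set. Compound 4 is estimated at 23%, between 8% and 38%.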

Compound 4, a percentage reported as activity, at one dose (the size of the read-out at that dose, not a potency): 22%
Estimate against measurement, compound 4: 1 percentage points above, and the stated range covers the measured number.
By their numbers in this assay, from the lowest: compounds 3, 1, 4 and 2 (each within the scatter of the next, the first and the last beyond it).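

In this assay, the change from carboxymethyl to carboxy on this saturated chain carbon gives a number 8.1 percentage points lower from compound 2 to compound 4 (within the scatter), so removing one chain carbon from the acid-bearing arm does not clearly separate these two compounds. At the shorter arm length, hydroxy in place of amino on a carbonyl carbon gives a number 5 percentage points higher from compound 1 to compound 4 (within the scatter), which means that the acid and the carbamoyl group cannot be told apart here, even though the earlier step gave a number 13.1 percentage points higher from compound 1 to compound 2 (beyond the scatter) and so lay beyond the scatter. That earlier gain therefore cannot be credited to the carboxylic acid alone, and nothing available explains why these numbers fall as they do.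

A 2-carbamoylethyl arm would complete the comparison by pairing an amide with the longer acid-bearing arm of compound 2, showing whether arm length or the acid carries that gain. On these data alone, it also remains open whether a longer chain ending in a carboxylic acid, or an amine in place of the acid, would raise or lower the number in this assay.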